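Benzofuran in place of the hydroxyethylphenyl: solubility outlook

This account rests on a few compounds, and the source may have more. Where it says the series, first, only, none or still open, it means among the compounds named here.

For the measured compounds named here, compound 2 `CNC(=O)c1cc(C(=O)NC2CC2)cn(Cc2cccc([C@@H](C)O)c2)c1=O` gives 495 ug/mL in a physicochemical assay for solubility, read by HPLC, in simulated intestinal fluid, with a stated time of 16 h, tested at 125 ug/mL (on this read-out higher numbers stand for higher solubility and lower numbers for lower solubility), the highest of the three numbers measured so far. Compound 1 `CNC(=O)c1cc(C(=O)NC2CCC2)cn(Cc2ccccc2)c1=O` gives 24 ug/mL in this assay. Compound 3 `CNC(=O)c1cc(C(=O)NC2CC2)cn(Cc2cccc3[nH]ccc23)c1=O` gives 17 ug/mL in this assay. Going by the values given here, the only single-point step that bears on the present case is a 29-fold lower number from compound 2 to compound 3 (1.46 log units; beyond the scatter), where a fused bicyclic aromatic group took the place of the 3-(1-hydroxyethyl)phenyl on a saturated chain carbon bound to an aromatic nitrogen.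

Compound 4 `CNC(=O)c1cc(C(=O)NC2CC2)cn(Cc2cccc3occc23)c1=O` has not yet been measured in this assay. Its difference from compound 2: 1-benzofuran-4-yl in place of 3-(1-hydroxyethyl)phenyl on a saturated chain carbon bound to an aromatic nitrogen. This change runs parallel to that giving compound 3: the 3-(1-hydroxyethyl)phenyl with its 1 hydrogen-bond donor and 1 defined stereocentre leaves, and a two-ring aromatic with 0 hydrogen-bond donors enters, here 1-benzofuran-4-yl rather than 1H-indol-4-yl. A large fall in this assay is therefore expected, close in size to the drop to compound 3 at 17 ug/mL. For compound 4 the expected step is a 41-fold lower number from compound 2 to compound 4 (1.62 log units; beyond the scatter). Compound 4 is estimated at 12 ug/mL in this assay, with a range from 4 ug/mL to 40 ug/mL.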

Compound 4, solubility: 74 ug/mL
Beside the measured number, compound 4's estimate is 6.2-fold (0.79 log units) below it; measured number above the stated range.
By their numbers in this assay, from the lowest: compounds 3 and 1 (each within the scatter of the next); then compound 4; then compound 2.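

In this assay, the fall on leaving 3-(1-hydroxyethyl)phenyl is not fixed for every two-ring aromatic at this place: the step to 1-benzofuran-4-yl is a 6.7-fold lower number from compound 2 to compound 4 (0.83 log units; beyond the scatter) and is only modest, against a 29-fold lower number from compound 2 to compound 3 (1.46 log units; beyond the scatter) for 1H-indol-4-yl. The two two-ring groups also separate from each other, with a 4.4-fold higher number from compound 3 to compound 4 (0.64 log units; beyond the scatter) on this exchange alone, so the identity of the five-membered ring's hetero atom matters here and the count of rings does not settle the number. No measurement at hand accounts for this gap between the two groups.

From the compounds shown here alone, compound 2 still holds the highest number of the series, and it remains open whether any two-ring group at this place can reach it. A carboxylic acid or a dimethylamino group on the 1-benzofuran-4-yl would test how far compound 4 can be lifted in this read-out.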